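Allyloxy in place of phenethylsulfanyl at the assay limit

The source may hold more compounds than are shown below. What is called first, only, known or untested is meant among the compounds shown, and "the series" means these compounds.

In a functional assay on SK-BR-3 cells (Homo sapiens) for antiproliferative activity, read by MTT assay, with a stated time of 72 h (a higher number here means a weaker inhibitor, a lower number a stronger inhibitor), compound 1 `C/C=C1/[C@H](O[C@@H]2O[C@H](COC(C)=O)[C@@H](OC(C)=O)[C@H](OC(C)=O)[C@H]2OC(C)=O)OC=C(C(=O)OC)[C@H]1CC(=O)OCCC1CCCCC1` gives a limit (> 15000 nM). Compound 2 `C/C=C1/[C@H](O[C@@H]2O[C@H](COC(C)=O)[C@@H](OC(C)=O)[C@H](OC(C)=O)[C@H]2OC(C)=O)OC=C(C(=O)OC)[C@H]1CC(=O)SCCc1ccccc1` gives a limit as well (> 15000 nM), so no number places it. The series offers only the limit of > 15000 nM in this assay, at which 2 of the 2 values shown sit, and one step of unreadable size (a step that the two limits leave unreadable from compound 1 to compound 2). Compound 3 `C=CCOC(=O)C[C@@H]1C(C(=O)OC)=CO[C@@H](O[C@@H]2O[C@H](COC(C)=O)[C@@H](OC(C)=O)[C@H](OC(C)=O)[C@H]2OC(C)=O)/C1=C/C` carries allyloxy in place of phenethylsulfanyl on a carbonyl carbon. With no readable step to lean on, the expected step in this assay (a step that the limit leaves unreadable from compound 2 to compound 3) has no direction, and none beyond the scatter is expected. Compound 3 is estimated at 20000 nM (expected range 8000 nM to 50000 nM).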

Compound 3, half-maximal inhibitory concentration: > 20000 nM
Compound 3: no number, only a limit (the forecaster's own chance of this, stated with the estimate: 75%); the middle value sits exactly at the limit.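

For the compounds shown here, compound 3 gives > 20000 nM, a limit and not a number, so no step linking it to compound 1 or compound 2 can be read. The compounds shown leave open whether any group on this carbonyl carbon gives a measurable value.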